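Chloro for methoxy on a second core

The source may report more compounds than this note shows. Statements on the series, on what has been measured and on what is new or still open speak of the compounds shown alone.

Measured compounds:
Compound 1, `COc1ccc(-c2[nH]c(=O)nc3nc(Nc4ccc(S(N)(=O)=O)cc4)sc23)cc1`: 667 nM
Compound 2, `NS(=O)(=O)c1ccc(Nc2nc3nc(=O)[nH]c(-c4ccc(Cl)cc4)c3s2)cc1`: 12700 nM
Compound 3, `COc1ccc(-c2[nH]c(=S)nc3nc(Nc4ccc(S(N)(=O)=O)cc4)sc23)cc1`: 667 nM

The study concerns three measured compounds and one still to be measured in a functional assay on Caco-2 cells (Homo sapiens) for cytotoxicity, read by MTT assay, with a stated time of 24 h; on this read-out higher numbers stand for weaker inhibition and lower numbers for stronger inhibition. Compound 1 gives 667 nM in this assay, and compound 3, built on a second core, gives 667 nM, so the two stand level with each other at the digits printed. The difference between the core of compound 1 and the core of compound 3 is not broken down here.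

One structural change is seen on the first core: from compound 1 to compound 2 the change is chloro in place of methoxy on an aromatic carbon, and it brings a 19-fold higher number from compound 1 to compound 2 (1.28 log units; beyond the scatter).

The unmeasured compound 4, `NS(=O)(=O)c1ccc(Nc2nc3nc(=S)[nH]c(-c4ccc(Cl)cc4)c3s2)cc1`, carries the same change on the second core: chloro in place of methoxy on an aromatic carbon. Both changes sit at the same place, on an aromatic carbon of a six-membered aromatic ring of carbon only, para to a large group, so this is the same change, made a second time.

For the measured compounds named here, since compound 3 starts level with compound 1 in this assay, and the only precedent is the step from compound 1 to compound 2, compound 4 is expected to show a step of about the same size, an 18-fold higher number from compound 3 to compound 4 (1.26 log units; beyond the scatter). Compound 4 is therefore estimated at 12000 nM, with a range from 4000 nM to 35000 nM, the width reflecting that the expectation rests on a single precedent.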

Compound 4, half-maximal inhibitory concentration: 333 nM
Compound 4: the middle estimate sits 36-fold (1.56 log units) above what was measured; measured number below the stated range.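

In this assay, the change from 4-methoxyphenyl to 4-chlorophenyl did not carry over from the core of compound 1 to the core of compound 3: the first core gives a 19-fold higher number from compound 1 to compound 2 (1.28 log units; beyond the scatter), whereas the second gives a 2.0-fold lower number from compound 3 to compound 4 (0.30 log units; within the scatter), a step that stays within the scatter. Read together, the two steps show that in this series the result of this change on one core cannot be taken as a guide to its result on the other: the same change on two cores in this assay, a 19-fold higher number (1.28 log units; beyond the scatter) from compound 1 to compound 2 and a 2.0-fold lower number (0.30 log units; within the scatter) from compound 3 to compound 4, 38-fold (1.58 log units) apart, beyond the scatter of two such steps. This rests on a single pair of compounds on each core, so it shows that the change behaves differently on these two cores but does not show why, nor whether the same would hold for any other change or any other core.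

The compounds shown leave open whether other groups at the same place on the ring, such as fluoro, methyl, an amine or a carboxylic acid, would also part ways between the two cores or would give matching steps on both. They also leave open whether the same disagreement between the two cores would appear for a change made elsewhere in the molecule, for instance at the sulfonamide.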